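The source may hold more compounds than are shown below. What is called first, only, known or untested is meant among the compounds shown, and "the series" means these compounds.

Measured so far:
- compound 1 `CC(C)(Sc1ncnc2c1ncn2[C@@H]1O[C@H](CO)[C@@H](O)[C@H]1O)c1ccccc1`: 21400 nM
- compound 2 `CSc1ncnc2c1ncn2C1CCCCO1`: 275000 nM

In an assay on isolated protein for binding affinity to Equilibrative nucleoside transporter 1 (Homo sapiens) (on this read-out higher numbers stand for weaker inhibition and lower numbers for stronger inhibition), compound 1 gives 21400 nM and holds the lower of the two numbers; compound 2, at 275000 nM, stands well above it, beyond the scatter. The two compounds differ in more than one place, so no single step can be read from that pair.

Compound 3 `Cc1ccc(CSc2ncnc3c2ncn3[C@@H]2O[C@H](CO)[C@@H](O)[C@H]2O)cc1` is the next case, not yet measured. It differs from compound 1 in one place: 4-methylbenzyl in place of 1-methyl-1-phenylethyl on a sulfur. For the measured compounds named here, no step between measured compounds covers this kind of exchange, so nothing in the numbers fixes its size or direction. The expectation is a modest shift towards a lower number, within a step of a 2.4-fold lower number from compound 1 to compound 3 (0.38 log units; beyond the scatter) from compound 1 to compound 3, not far beyond the scatter. On that basis compound 3 is estimated at 9000 nM, with a range from 2500 nM to 35000 nM.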

Compound 3, half-maximal inhibitory concentration: 457 nM
For compound 3 the middle estimate is 20-fold (1.29 log units) above the measured one; measured number below the stated range.
By their numbers in this assay, from the lowest: compound 3; then compound 1; then compound 2.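

The group on the sulfur strongly influences the number in this assay: 4-methylbenzyl in place of 1-methyl-1-phenylethyl gives a 47-fold lower number from compound 1 to compound 3 (1.67 log units; beyond the scatter), a large step for an exchange between two groups that each carry one six-membered aromatic ring of carbon only and no net charge. The presence of such a ring therefore does not by itself set the number at this position, as compound 1 and compound 3 both have one. No measured evidence bears on the reason for this step.

The exchange alters both the carbon attached to the sulfur and the methyl on the ring, so an unsubstituted benzyl group would be needed to separate the two changes. Also open, as far as these compounds go, is how a longer chain between sulfur and ring, or a methoxy or nitro group on the ring, would read out.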